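Oral exposure in mice after a hydroxy-for-methylsulfonyl swap

The source may hold more compounds than are shown below. What is called first, only, known or untested is meant among the compounds shown, and "the series" means these compounds.

The compounds measured so far:
compound 1 `CC1=C(c2ccc(S(C)(=O)=O)cc2)C(c2ccc(OC[C@H](C)N3CC[C@@H](C)C3)cc2)Oc2ccc(O)cc21` — "not determined" (no result reported)
compound 2 `CC1=C(c2ccc(C#N)cc2)C(c2ccc(OC[C@H](C)N3CC[C@@H](C)C3)cc2)Oc2ccc(O)cc21` — 2000 ng.h/mL
compound 3 `CC1=C(c2cccc(S(C)(=O)=O)c2)C(c2ccc(OC[C@H](C)N3CC[C@@H](C)C3)cc2)Oc2ccc(O)cc21` — "not determined" (no result reported)

All three share one core and the same pyrrolidine-bearing side chain; they differ only in the aryl group that sits on the double bond of the core. In an ADME assay on the whole organism for pharmacokinetics, with Mus musculus as the target, at a dose of 10 mg/kg by the oral route (a lower number here means less compound in the circulation, a higher number more compound in the circulation at the dose given), compound 2 gives 2000 ng.h/mL. For compound 3 no single number exists in this assay, and compound 1 is the one further entry without a number, so compound 3 cannot be placed relative to compound 2 on the numbers shown.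

The next compound, compound 4 `CC1=C(c2cccc(O)c2)C(c2ccc(OC[C@H](C)N3CC[C@@H](C)C3)cc2)Oc2ccc(O)cc21`, is reached from compound 3 by one change: hydroxy in place of methylsulfonyl on an aromatic carbon. Among the measured compounds shown here, no measured pair with this change is available. In this assay the step from compound 3 to compound 4 is expected to be modest, most likely a drop rather than a rise, though a step inside the usual scatter cannot be excluded.

Taking compound 2 as the only anchor with a number, compound 4 is estimated to give 800 ng.h/mL in this assay, with a range from 150 ng.h/mL to 3000 ng.h/mL.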

Compound 4, area under the concentration-time curve: 590 ng.h/mL
Compound 4: middle estimate off by 1.4-fold (0.13 log units), on the high side; the measured number falls inside the stated range.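

In this assay the record now holds a 3.4-fold lower number from compound 2 to compound 4 (0.53 log units; beyond the scatter) with 3-hydroxyphenyl in place of 4-cyanophenyl, so the aryl group on the double bond of the shared core is shown for the first time to matter for this read-out, by a step beyond the usual scatter. This step changes both the group and where it sits on the ring, so the numbers cannot assign it to the hydroxy, to the loss of the nitrile, or to the new place alone. Nothing available bears on why the number is lower in compound 4.

Steps that involve compound 1 or compound 3 cannot be read, as neither has a single number in this assay, which leaves the effect of hydroxy in place of methylsulfonyl open. On these data alone, it also remains open how a nitrile, an amine or a carboxylic acid in place of the hydroxy of compound 4 would compare, and the first of these would separate the group from its place on the ring.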